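A few compounds are considered here, and "the series" means these few. Any claim that something is new, unique, unknown or untested is made for them only; others in the source may bear on it.

In a functional assay on K562 cells (Homo sapiens) for cytotoxicity, read by MTT assay, with a stated time of 24 h (on this read-out higher numbers stand for weaker inhibition and lower numbers for stronger inhibition), compound 1, with the structure `C[C@H](NC(=O)c1ccccc1)c1n[nH]c(=S)o1`, gives 377000 nM. Compound 2, `C[C@H](NC(=O)c1ccc(Cl)cc1)c1n[nH]c(=S)o1`, carries the change chloro in place of hydrogen on an aromatic carbon and in this assay gives 31100 nM, so that the step of a 12-fold lower number from compound 1 to compound 2 (1.08 log units; beyond the scatter) is a large one. Compound 3, `C[C@H](NC(=O)c1ccccc1)c1n[nH]c(=S)n1N`, has a different core from compound 1, and the difference between the two cores is not broken down here; in this assay compound 3 gives 372000 nM, and its value and that of compound 1 lie within the scatter of each other. Compound 4, `C[C@H](NC(=O)c1ccc(Cl)cc1)c1n[nH]c(=S)n1N`, is not yet measured; it differs from compound 3 by chloro in place of hydrogen on an aromatic carbon, the same change seen from compound 1 to compound 2. Because compound 1 gives 377000 nM and compound 3 gives 372000 nM in this assay, values that sit within the scatter of each other, the author expects the change on the second core to behave much as it did on the first, so that the step of a 9.3-fold lower number from compound 3 to compound 4 (0.97 log units; beyond the scatter) is estimated to land near the earlier one, with a little allowance for the two cores not being the same. On that basis compound 4 is expected to give about 40000 nM in this assay, most likely between 12000 nM and 150000 nM.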

Compound 4, half-maximal inhibitory concentration: 98600 nM
Estimate against measurement, compound 4: 2.5-fold (0.39 log units) below; the measured number falls inside the stated range.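

In this assay, chloro in place of hydrogen on an aromatic carbon again lowers the number on the second core, giving a 3.8-fold lower number from compound 3 to compound 4 (0.58 log units; beyond the scatter), so the direction of the change carries over from the core of compound 1 to the core of compound 3, but its size does not: the same change on two cores in this assay, a 12-fold lower number (1.08 log units; beyond the scatter) from compound 1 to compound 2 and a 3.8-fold lower number (0.58 log units; beyond the scatter) from compound 3 to compound 4, 3.2-fold (0.51 log units) apart, beyond the scatter of two such steps. The two cores therefore cannot be treated as interchangeable for this change, even though compound 1 and compound 3 lie within the scatter of each other without the chloro group. With a single pair on each core, these results do not show why the step differs in size, nor whether the same difference between cores would appear with any other group.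

The compounds shown leave open how a fluoro, methoxy or nitro group would behave in the same place on the aromatic ring on each core. They also leave open whether a longer chain in place of the methyl group would change the picture.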